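The source may hold more compounds than are shown below. What is called first, only, known or untested is meant among the compounds shown, and "the series" means these compounds.

Compound 1 `CNC(=O)c1cc(C(=O)N[C@H]2CC[C@H](O)CC2)c([C@@H](C)c2ccccc2Cl)o1` and compound 2 `CNC(=O)c1cc(C(=O)NC2CC2)cn([C@@H](C)c2ccccc2)c1=O` were measured in a physicochemical assay for solubility, read by HPLC, in simulated intestinal fluid, with a stated time of 16 h, at pH 6.5; on this read-out lower numbers stand for lower solubility and higher numbers for higher solubility. Compound 1 sits at the limit of > 1000 ug/mL in this assay, at which 1 of the 2 values shown sits, so only a limit is known for it: in this assay compound 1 gives > 1000 ug/mL. In this assay compound 2 gives 699 ug/mL. Compound 3 `CNC(=O)c1cc(C(=O)N[C@H]2CC[C@H](O)CC2)c([C@@H](C)c2ccccc2)o1` has not yet been measured; it differs from compound 1 by hydrogen in place of chloro on an aromatic carbon. Among the compounds with values here, no step between measured compounds is available. Compound 3 is expected to remain at or near the limit, with the step that the limit leaves unreadable from compound 1 to compound 3 expected to lie within the scatter. The estimated value of compound 3 in this assay is 1500 ug/mL, in a range from 700 ug/mL to 3000 ug/mL.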

Compound 3, solubility: 827 ug/mL
Compound 3: the middle estimate sits 1.8-fold (0.26 log units) above what was measured; measured number inside the range.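

In this assay, hydrogen in place of chloro on this aromatic carbon gives an at least 1.2-fold lower number from compound 1 to compound 3 (0.08 log units; that floor lies within the scatter). Within the data shown here, compound 3 provides the first number on the core of compound 1 that is not a limit, so this change now has a readable value on one side only. The full size of the step stays unknown, because only its floor can be read: the limit of > 1000 ug/mL in this assay, at which 1 of the 3 values shown sits.

The compounds shown leave open how far the step extends beyond that floor. They also leave open how a methoxy group or a carboxylic acid on this aromatic carbon would read in this assay.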